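Swapping the difluorophenyl for a nitrophenyl

The source may report more compounds than this note shows. Statements on the series, on what has been measured and on what is new or still open speak of the compounds shown alone.

Compound 2 `Fc1ccc(CSc2nnc(-c3ccncc3)n2-c2ccccc2)c(F)c1` and compound 1 `Brc1cccc(CSc2nnc(-c3ccncc3)n2-c2ccccc2)c1` share one core and differ only in the group on a saturated chain carbon bound to a sulfur. In a functional assay on MCF7 cells (Homo sapiens) for inhibition, read by MTT assay, with a stated time of 48 h (a lower number here means a stronger inhibitor, a higher number a weaker inhibitor), compound 1 gives 10000 nM, and compound 2 gives 14100 nM. Within the data shown here, the single measured step, a 1.4-fold higher number from compound 1 to compound 2 (0.15 log units; within the scatter), leaves the two compounds indistinguishable, so compound 2 has no neighbour that differs from it beyond the scatter. Compound 3 `O=[N+]([O-])c1ccc(CSc2nnc(-c3ccncc3)n2-c2ccccc2)cc1` has not yet been measured; its change from compound 2 is 4-nitrophenyl in place of 2,4-difluorophenyl on a saturated chain carbon bound to a sulfur. Among the measured compounds shown here, the only comparison that bears on this change is the exchange of one aromatic group for another between compound 1 and compound 2, which stayed within the scatter. A 4-nitrophenyl has not been tried here, so no direction can be read from the data. Compound 3 is therefore expected to show a 1.2-fold lower number from compound 2 to compound 3 (0.07 log units; within the scatter), no step beyond the scatter. The estimated value for compound 3 in this assay is 12000 nM, with a range from 4000 nM to 40000 nM.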

Compound 3, half-maximal inhibitory concentration: 22800 nM
The estimate for compound 3 lay 1.9-fold (0.28 log units) below the measured number; the measured number falls inside the stated range.
By their numbers in this assay, from the lowest: compounds 1, 2 and 3 (each within the scatter of the next, the first and the last beyond it).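

In this assay, among these compounds, the step of a 1.6-fold higher number from compound 2 to compound 3 (0.21 log units; within the scatter) stays too small to count, but the step of a 2.3-fold higher number from compound 1 to compound 3 (0.36 log units; beyond the scatter) is the first change at this position that clears the usual noise, if only modestly. The group on a saturated chain carbon bound to a sulfur can therefore shift the number: 4-nitrophenyl gives a weaker inhibitor than 3-bromophenyl, while 2,4-difluorophenyl cannot be told apart from either of them. Nothing shown here offers a reason for this difference.

Going by these compounds, all three compounds carry a substituted phenyl on this carbon, so it remains open how far the number could move, and in which direction, with a different kind of group. An amine, a carboxylic acid or a longer chain at this place could show whether any change here yields a clearly stronger inhibitor.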